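This account rests on a few compounds, and the source may have more. Where it says the series, first, only, none or still open, it means among the compounds named here.

Measured so far in an assay for binding affinity to dual specificity mitogen-activated protein kinase kinase 4 (Homo sapiens), read by KINOMEscan, tested at 100 nM; a higher number here means a weaker effect of the compound at the concentration tested, a lower number a stronger effect:
compound 1, `CCCS(=O)(=O)Nc1ccc(F)c(C(=O)c2n[nH]c3ncc(-c4cccc(OC)c4)cc23)c1F`, gives 6.3%
compound 2, `CCCS(=O)(=O)Nc1ccc(F)c(C(=O)c2n[nH]c3ncc(-c4ccc(OC)cc4)cc23)c1F`, gives 4.2%
compound 3, `CCCS(=O)(=O)Nc1ccc(F)c(C(=O)c2n[nH]c3ncc(-c4cc(Cl)cc(Cl)c4)cc23)c1F`, gives 73%

Compound 3 stands at the highest of the three numbers in this assay, and both of its steps from the other compounds are beyond the scatter: a number 66.7 percentage points higher from compound 1 to compound 3 (beyond the scatter) and a number 68.8 percentage points higher from compound 2 to compound 3 (beyond the scatter). Between compounds 1 and 2 the step is small, a number 2.1 percentage points lower from compound 1 to compound 2 (within the scatter), so the two methoxyphenyl compounds are read as alike.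

The step to the unmeasured compound 4, `CCCS(=O)(=O)Nc1ccc(F)c(C(=O)c2n[nH]c3ncc(-c4ccc([N+](=O)[O-])cc4)cc23)c1F`, is this change: 4-nitrophenyl in place of 3,5-dichlorophenyl on an aromatic carbon

The two large steps bearing on it, from compound 1 to compound 3 and from compound 2 to compound 3, both show that replacing a methoxyphenyl by the 3,5-dichlorophenyl goes with a much higher number. Among the compounds with values here, compound 4 leaves the 3,5-dichlorophenyl and returns to a singly substituted phenyl, so the expected direction is back downward, though no measured compound carries a nitro group and the size is uncertain. For compound 4 a drop of about a number 48 percentage points lower from compound 3 to compound 4 (beyond the scatter) is expected. Compound 4 is therefore estimated at 25%, within a wide range from 3% to 70%.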

Compound 4, a percentage reported as activity, at one concentration (the size of the read-out at that concentration, not a potency): 4.2%
Beside the measured number, compound 4's estimate is 20.8 percentage points above it; the measured number falls inside the stated range.
By their numbers in this assay, from the lowest: compounds 2, 4 and 1 (each within the scatter of the next); then compound 3.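

In this assay the 4-nitrophenyl group at this position goes with a low number again, with a number 68.8 percentage points lower from compound 3 to compound 4 (beyond the scatter), so a single phenyl substituent that is neither methoxy nor chlorine sits on the same low side as the methoxyphenyl groups. The nitro group reads like methoxy at the same ring position, with no change at the digits printed from compound 2 to compound 4 (within the scatter), and the comparison with the other methoxy placement gives a number 2.1 percentage points lower from compound 1 to compound 4 (within the scatter), so among these four compounds the high number belongs to compound 3 alone. No measurement shown here explains why the 3,5-dichlorophenyl group stands apart.

Going by these compounds, whether one chlorine, as in a 3-chlorophenyl or 4-chlorophenyl group, already raises the number or both chlorines are needed remains open. On these data alone, it is also open what an amine or a carboxylic acid on the phenyl ring would give, and how compounds 1, 2 and 4 might separate at a lower concentration than the single one tested.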